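The source may report more compounds than this note shows. Statements on the series, on what has been measured and on what is new or still open speak of the compounds shown alone.

In a functional assay on HepG2 cells (Homo sapiens) for inhibition, read by MTT assay, with a stated time of 48 h, tested at 10 uM (a lower number here means less inhibition of growth, a higher number more inhibition of growth at the concentration tested), the measured compounds are:

compound 1, `COc1ccc(C(=O)/C=C/c2ccc(OCc3cn(Cc4ccc(F)cc4)nn3)cc2)cc1`: 21%
compound 2, `O=C(/C=C/c1ccc(OCc2cn(Cc3cccc(Br)c3)nn2)cc1)c1ccc([N+](=O)[O-])cc1`: 13%

Compound 2 gives the lower of the two numbers, and compound 1 sits somewhat higher, but the gap between them lies within the usual scatter of this kind of measurement, so the two results cannot be told apart. Among the compounds with values here, compound 1 and compound 2 differ from each other in more than one place, so no single step connects them and nothing can be read from their pair beyond what the two values show.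

Compound 3, `O=C(/C=C/c1ccc(OCc2cn(Cc3ccc(F)cc3)nn2)cc1)c1ccc([N+](=O)[O-])cc1`, has not yet been measured. It differs from compound 2 in one place: 4-fluorophenyl in place of 3-bromophenyl on a saturated chain carbon bound to an aromatic nitrogen. The rest of compound 2 stays as it is. The group that enters is the same one that compound 1 carries on its saturated chain carbon, and compound 1 and compound 2 give numbers within the scatter of each other. On that basis no step beyond the scatter is expected in this assay, in either direction. The expected step is a number 3 percentage points higher from compound 2 to compound 3 (within the scatter). Compound 3 is estimated at 16%, with a range from 6% to 28%.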

Compound 3, percent growth inhibition at one concentration: 25%
The estimate for compound 3 lay 9 percentage points below the measured number; low and high end bracket the measured number.
By their numbers in this assay, from the lowest: compounds 2, 1 and 3 (each within the scatter of the next, the first and the last beyond it).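

In this assay, 4-fluorophenyl in place of 3-bromophenyl on a saturated chain carbon bound to an aromatic nitrogen gives a number 12 percentage points higher from compound 2 to compound 3 (beyond the scatter), a modest step and the first one here beyond the scatter, so the group at this position can change the growth inhibition seen at the concentration tested. The two groups have the same count of heavy atoms and differ in both the halogen and its place on the ring, so this step cannot be assigned to either difference alone. At the other end of the molecule, with 4-fluorophenyl kept, nitro in place of methoxy on an aromatic carbon gives a number 4 percentage points higher from compound 1 to compound 3 (within the scatter), which lies within the scatter, and no measurement is available that explains either result.

Going by these compounds, it remains open whether the halogen or its place on the ring matters more, a question that 4-bromophenyl or 3-fluorophenyl at the same position could help settle. On these data alone, it is also open how an amine or a carboxylic acid in place of nitro on the aromatic carbon would read in this assay.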